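Moving from 4-chlorophenyl to 2-iodophenyl on the amide

The source may hold more compounds than are shown below. What is called first, only, known or untested is meant among the compounds shown, and "the series" means these compounds.

Compound 1 `COc1cc2ncnc(Nc3ccc(NC(=O)c4ccccc4OC)cc3)c2cc1OC`: > 100000 nM, a limit of the assay
Compound 2 `COc1cc2ncnc(Nc3ccc(NC(=O)c4ccc(Cl)cc4)cc3)c2cc1OC`: 30000 nM

Within the data shown here, in a functional assay on MCF7 cells (Homo sapiens) for inhibition, read by MTT assay (on this read-out higher numbers stand for weaker inhibition and lower numbers for stronger inhibition), compound 2 gives 30000 nM, the only actual number so far. The sole other result, that of compound 1, is a limit. Compound 3 `COc1cc2ncnc(Nc3ccc(NC(=O)c4ccccc4I)cc3)c2cc1OC` arises from compound 2 through (2-iodophenyl in place of 4-chlorophenyl on a carbonyl carbon). Among the measured compounds shown here, one measured step bears on this change: the 2-methoxyphenyl of compound 1 gave way to 4-chlorophenyl in an at least 3.3-fold lower number from compound 1 to compound 2 (0.52 log units; beyond the scatter), which lies beyond the scatter. With 2-iodophenyl now leaving that 4-chlorophenyl behind, a modest move toward weaker inhibition is expected, namely a 1.7-fold higher number from compound 2 to compound 3 (0.22 log units; within the scatter). Compound 3 is estimated at 50000 nM, with an expected range of 15000 nM to 100000 nM.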

Compound 3, half-maximal inhibitory concentration: 37000 nM
The estimate for compound 3 lay 1.4-fold (0.13 log units) above the measured number, within the range that was stated.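

In this assay, 2-iodophenyl in place of 4-chlorophenyl on the carbonyl carbon gives a 1.2-fold higher number from compound 2 to compound 3 (0.09 log units; within the scatter), so the two groups cannot be told apart here. Iodo in place of methoxy on an aromatic carbon gives an at least 2.7-fold lower number from compound 1 to compound 3 (0.43 log units; beyond the scatter), so the gain first seen with 4-chlorophenyl is also reached with 2-iodophenyl. Compound 1 stands at a limit, not a number: the limit of > 100000 nM in this assay, at which 1 of the 3 values shown sits.

Still open, going by these compounds, is whether any group at this place moves the number well past compound 2 and compound 3. On these data alone, how an aminophenyl or a carboxyphenyl on the same carbonyl carbon would read also remains unknown.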